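A Third Methoxy Group on the Benzyl Ring

This account rests on a few compounds, and the source may have more. Where it says the series, first, only, none or still open, it means among the compounds named here.

Compound 1, `COc1ccc(CN(C(=O)Nc2ccc(Cl)cc2)n2cnnc2)cc1OC`, gives 20400 nM in a functional assay on DU-145 cells (Homo sapiens) for cytotoxicity, read by MTT assay, with a stated time of 48 h; on this read-out lower numbers stand for stronger inhibition and higher numbers for weaker inhibition.
Compound 2, `COc1ccc(CN(C(=O)Nc2ccc(C#N)cc2)n2cnnc2)cc1OC`, gives 24100 nM in this assay.

Both measured compounds share the same core and differ only on the aromatic ring that carries the urea nitrogen. Compound 2 stands at one end of the two numbers shown, yet the single measured step, a 1.2-fold higher number from compound 1 to compound 2 (0.07 log units; within the scatter), lies within the scatter, so the two compounds cannot be told apart on this evidence.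

Compound 3, `COc1cc(CN(C(=O)Nc2ccc(C#N)cc2)n2cnnc2)cc(OC)c1OC`, keeps the cyano-bearing ring of compound 2 and changes the other ring instead: methoxy in place of hydrogen on an aromatic carbon. The new group sits ortho to a methoxy group and meta to a second methoxy group, on the ring that already carries two of them.

Among the measured compounds shown here, no measured step bears directly on this change: the only step on record concerns a swap on the far ring, and it was within the scatter. With nothing pointing either way, compound 3 is expected to show no step beyond the scatter, a 1.0-fold lower number from compound 2 to compound 3 (0.00 log units; within the scatter). The estimate for compound 3 is therefore 24000 nM, within a range from 8000 nM to 70000 nM.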

Compound 3, half-maximal inhibitory concentration: 20600 nM
Estimate against measurement, compound 3: 1.2-fold (0.07 log units) above; low and high end bracket the measured number.
By their numbers in this assay, from the lowest: compounds 1, 3 and 2 (each within the scatter of the next).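

On the ring that already carries two methoxy groups, a third one leaves the result in this assay unresolved from that of compound 2 (a 1.2-fold lower number from compound 2 to compound 3 (0.07 log units; within the scatter)), a step that lies within the scatter. Among the compounds shown here, this is the first information on this ring, since the earlier step concerned only the other ring, and it shows that at this position, ortho to a methoxy group and meta to a second methoxy group, replacing hydrogen with methoxy produces no step that can be told from repeat-measurement noise. There is no measurement at hand that would explain this outcome.

The compounds shown leave open whether any other group at this position, such as an amine, a carboxylic acid or a longer chain, would move the number beyond the scatter. They also leave open whether the third methoxy group would behave the same way with the chloro group of compound 1 on the other ring, as only the cyano-bearing pair has been compared here.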